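Fluoro to hydrogen on an aromatic carbon: efficacy outlook

The compounds below may be only part of what the source reports. "The series", "measured", "known", "first", "only" and "open" are said of these compounds alone.

Compound 1 `O=C(O)CCc1ccc(C#Cc2ccnc(F)c2)cc1` gives 98% in an in vitro functional assay on 1321-N1 cells for agonist activity at Free fatty acid receptor 1 (Homo sapiens), read by fluorescence, spectrophotometry and calcium flux; a higher number here means a larger maximal response, a lower number a smaller maximal response. Among the three measured compounds it stands second highest, nearest to compound 3 `Cc1cnc(F)cc1C#Cc1ccc(CCC(=O)O)cc1` with 99% and furthest from compound 2 `Cc1c(C#Cc2ccc(CCC(=O)O)cc2)cc(Cl)nc1Cl` with 91%; both gaps lie within the scatter. Among the compounds with values here, the only step measured between compounds differing in one place is a number 1 percentage points higher from compound 1 to compound 3 (within the scatter), a change at the same ring that stayed within the scatter. Compound 4 `O=C(O)CCc1ccc(C#Cc2ccncc2)cc1` differs from compound 1 by hydrogen in place of fluoro on an aromatic carbon. Within the data shown here, no measured step removes fluoro, so the expectation rests on the flat outcome of a number 1 percentage points higher from compound 1 to compound 3 (within the scatter) and on all three values sitting within the scatter of one another. The expected step is a number 3 percentage points lower from compound 1 to compound 4 (within the scatter), none beyond the scatter. Compound 4 is estimated at 95%, in the range 80% to 106%.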

Compound 4, largest response reached (reported as efficacy), in percent of the reference or control that the assay uses: 100%
The estimate for compound 4 lay 5 percentage points below the measured number, and the stated range covers the measured number.
By their numbers in this assay, from the lowest: compounds 2, 1, 3 and 4 (each within the scatter of the next).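

Hydrogen in place of the fluoro next to the ring nitrogen leaves the maximal response flat in this assay, with a number 2 percentage points higher from compound 1 to compound 4 (within the scatter). The fluoro is therefore not needed at this position to keep the response of the core of compound 1 within the scatter, and the same holds for this one pair only. No available data bear on why this exchange leaves the response unchanged.

As far as these compounds go, whether a larger group at this carbon, such as an amine or methoxy, would also keep the response remains open. Maximal response alone also leaves open whether potency is equally insensitive to this change.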